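Amino chains on the shared core: PC-3 working notes

A few compounds are considered here, and "the series" means these few. Any claim that something is new, unique, unknown or untested is made for them only; others in the source may bear on it.

- compound 1 `CCCC(C)Oc1c(-c2cc(OC)c(OC)c(OC)c2)oc2ccccc2c1=O`: 49300 nM
- compound 2 `CCCN(CCC)CCCCCOc1c(-c2cc(OC)c(OC)c(OC)c2)oc2ccccc2c1=O`: 2600 nM

In a functional assay on PC-3 cells (Homo sapiens) for antiproliferative activity, read by WST assay, with a stated time of 3 days (a higher number here means a weaker inhibitor, a lower number a stronger inhibitor), compound 2 holds the lower of the two numbers at 2600 nM. Compound 3 `CCCCN(CCCC)CCCOc1c(-c2cc(OC)c(OC)c(OC)c2)oc2ccccc2c1=O` is still unmeasured. Its change from compound 2 is dibutylamino in place of 2-(dipropylamino)ethyl on a saturated chain carbon, three bonds along the chain from an oxygen on an aromatic ring, which puts dibutylamino in place of 2-(dipropylamino)ethyl on a saturated chain carbon, three bonds along the chain from an oxygen on an aromatic ring. Read one cut further out, this is 5-(dipropylamino)pentyl to 3-(dibutylamino)propyl.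

For the measured compounds named here, the only measured step, a 19-fold lower number from compound 1 to compound 2 (1.28 log units; beyond the scatter), is large, but it replaces 1-methylbutyl, a chain with no amino group. Going by the values given here, no measured step exchanges one amino chain for another, so it bears on this change only loosely. Compound 3 also carries an amino chain, so no step beyond the scatter is expected in this assay, and no direction is favoured. The estimated step is a 1.2-fold higher number from compound 2 to compound 3 (0.06 log units; within the scatter). The estimate for compound 3 is 3000 nM, with an expected range of 1000 nM to 9000 nM.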

Compound 3, half-maximal inhibitory concentration: 7100 nM
Beside the measured number, compound 3's estimate is 2.4-fold (0.37 log units) below it, within the range that was stated.
By their numbers in this assay, from the lowest: compound 2; then compound 3; then compound 1.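

In this assay, the exchange of dibutylamino for 2-(dipropylamino)ethyl at this position, with the same atoms joined differently, gives a 2.7-fold higher number from compound 2 to compound 3 (0.44 log units; beyond the scatter). An amino chain in place of the 1-methylbutyl chain therefore does not fix the number on its own, since 3-(dibutylamino)propyl gives a 6.9-fold lower number from compound 1 to compound 3 (0.84 log units; beyond the scatter), a smaller step than a 19-fold lower number from compound 1 to compound 2 (1.28 log units; beyond the scatter). Nothing available explains the difference between the two amino chains.

Between compound 2 and compound 3, the pentyl chain becomes propyl while the propyl groups on the nitrogen become butyl, so the two changes cannot be read apart. The compounds shown leave open how 5-(dibutylamino)pentyl, 3-(dipropylamino)propyl or a cyclic amine such as piperidine on the chain would read in this assay.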